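The compounds below may be only part of what the source reports. "The series", "measured", "known", "first", "only" and "open" are said of these compounds alone.

Among the measured compounds shown here, compound 3, `O=C1O[C@@H](Cn2ccnc2)CN1c1ccc(-n2cc(-c3ccccn3)cn2)c(F)c1`, is the compound with the lowest number of the three measured so far in a physicochemical assay for lipophilicity, read by HPLC, measured as octanol-water partition (on this read-out higher numbers stand for higher lipophilicity and lower numbers for lower lipophilicity), where it gives 1.73. Its nearest neighbour is compound 1, `COC(=O)CC1CCN(C[C@H]2CN(c3ccc(-n4cc(-c5ccccn5)cn4)c(F)c3)C(=O)O2)CC1`, which in this assay gives 1.78; the two values lie within the scatter of each other. Far away stands compound 2, `O=C1O[C@@H](CN2CCC(c3ccc(F)cc3)CC2)CN1c1ccc(-n2cc(-c3ccccn3)cn2)c(F)c1`, which in this assay gives 5.78. The two measured steps are a number 0.05 log units lower from compound 1 to compound 3 (within the scatter) and a number 4.00 log units higher from compound 1 to compound 2 (beyond the scatter).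

Compound 4, `CONC(=O)[C@H]1CN(c2ccc(-n3cc(-c4ccccn4)cn3)c(F)c2)C(=O)O1`, differs from compound 3 in one place: methoxycarbamoyl in place of (1H-imidazol-1-yl)methyl on a saturated ring carbon. Neither measured step shows this exact exchange. The step from compound 1 to compound 3 swaps two groups at the same position and is within the scatter, so a change at that position does not by itself move the number much. The large step from compound 1 to compound 2 concerns a group that compound 4 does not carry and so gives little guidance. With an imidazole ring leaving and a small amide-like group with one hydrogen-bond donor entering, a step near the scatter or slightly downward is expected, estimated as a number 0.23 log units lower from compound 3 to compound 4 (within the scatter). Compound 4 is therefore expected to give about 1.5, with a likely range from 0.8 to 2.2.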

Compound 4, partition coefficient: >= 1.58
Compound 4: only a limit was reported (the forecaster's own chance of this, stated with the estimate: 0%); at least 0.08 log units between middle value and limit.
By their numbers in this assay, from the lowest: compounds 3 and 1 (each within the scatter of the next); then compound 2.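

In this assay compound 4 gives >= 1.58, which is a limit and not a number. Its steps from compound 3 and from compound 1 therefore cannot be read. The compounds shown leave open what number compound 4 would give, and so how far methoxycarbamoyl in place of (1H-imidazol-1-yl)methyl moves the read-out.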